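This account rests on a few compounds, and the source may have more. Where it says the series, first, only, none or still open, it means among the compounds named here.

Compounds measured so far:
compound 1, `Cc1ccccc1Cc1cnc(CCc2ccc(-c3ccccc3C(=O)O)cc2)[nH]1`, 127 nM
compound 2, `N#Cc1ccc(Cc2cnc(CCc3ccc(-c4ccccc4C(=O)O)cc3)[nH]2)cc1`, 5890 nM
compound 3, `CC(C)(C)CCc1cnc(CCc2ccc(-c3ccccc3C(=O)O)cc2)[nH]1`, 39 nM

In an in vitro functional assay on cells for agonist activity at Bombesin receptor subtype-3 (Homo sapiens), read by luminescence and calcium flux (on this read-out lower numbers stand for an effect already at smaller amounts and higher numbers for an effect only at larger amounts of compound), compound 1 stands second highest of the three numbers. Its nearest neighbour is compound 3, reached by a 3.3-fold lower number from compound 1 to compound 3 (0.51 log units; beyond the scatter); the furthest is compound 2, reached by a 46-fold higher number from compound 1 to compound 2 (1.67 log units; beyond the scatter). Both steps change the same position and both lie beyond the scatter, so the group on the saturated chain carbon bound to the aromatic carbon plainly matters to this assay.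

Compound 4, `CCC(C)(CC)Cc1cnc(CCc2ccc(-c3ccccc3C(=O)O)cc2)[nH]1`, has not yet been measured. It differs from compound 1 by 1-ethyl-1-methylpropyl in place of 2-methylphenyl on a saturated chain carbon bound to an aromatic carbon. Within the data shown here, the step that bears on it most directly is the one from compound 1 to compound 3, where a branched alkyl group replaced the same 2-methylphenyl group and gave a modest lowering. The 1-ethyl-1-methylpropyl group of compound 4 is likewise a branched alkyl group, larger by one carbon than neopentyl, so a lowering of about the same size is expected rather than anything resembling the large rise seen toward compound 2.

Compound 4 is therefore estimated at 45 nM, within a range of 15 nM to 150 nM, which would be a step of a 2.8-fold lower number from compound 1 to compound 4 (0.45 log units; beyond the scatter).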

Compound 4, half-maximal effective concentration: 76 nM
Compound 4: the middle estimate sits 1.7-fold (0.23 log units) below what was measured; the range from low to high includes it.
By their numbers in this assay, from the lowest: compounds 3, 4 and 1 (each within the scatter of the next, the first and the last beyond it); then compound 2.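

In this assay, the 1-ethyl-1-methylpropyl group of compound 4 cannot be told apart from the 2-methylphenyl group (a 1.7-fold lower number from compound 1 to compound 4 (0.22 log units; within the scatter)) or from the neopentyl group (a 1.9-fold higher number from compound 3 to compound 4 (0.29 log units; within the scatter)), even though compound 1 and compound 3 lie beyond the scatter of each other. At this place, on a saturated chain carbon bound to an aromatic carbon, a second branched alkyl group with no ring therefore stays in the same range as compound 1, which does carry a ring, while compound 2 remains far apart (a 78-fold lower number from compound 2 to compound 4 (1.89 log units; beyond the scatter)); ring against no ring does not by itself account for the gap, and compound 2 stands alone among the four. No measurement is available here that would explain these values.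

From the compounds shown here alone, whether a plain phenyl group at this place would fall with compound 1 or with compound 2 stays open, and with it how much of the gap belongs to the nitrile. Equally open, going by these compounds, is how an unbranched chain such as n-hexyl, or an alkyl group carrying an amine or a hydroxyl, would fare at this place.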